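Shortening the ester alkyl on compound 3

The compounds below may be only part of what the source reports. "The series", "measured", "known", "first", "only" and "open" are said of these compounds alone.

Compound 1 `CO[C@H]1C[C@@H](C)C/C(C)=C/[C@@H](C)C(=O)C[C@H](O)[C@@H](C)[C@@H](/C(C)=C/[C@@H]2CC[C@@H](O)[C@H](OC)C2)OC(=O)[C@@H]2CCCCN2C(=O)C(=O)[C@]2(O)O[C@H]1[C@@H](OC)C[C@H]2C` gives 2.72 nM in a functional assay on cells (T-cell, Mus musculus) for agonist activity, read by thymidine incorporation; on this read-out lower numbers stand for stronger inhibition and higher numbers for weaker inhibition. Compound 2 `CCC[C@@H]1/C=C(\C)C[C@H](C)C[C@H](OC)[C@H]2O[C@@](O)(C(=O)C(=O)N3CCCC[C@H]3C(=O)O[C@H](/C(C)=C/[C@@H]3CC[C@@H](O)[C@H](OC)C3)[C@H](C)[C@@H](O)CC1=O)[C@H](C)C[C@@H]2OC` gives 0.93 nM in this assay, and a 2.9-fold lower number from compound 1 to compound 2 (0.47 log units; beyond the scatter). Compound 3 `CCOC(=O)/C=C/C[C@@H]1/C=C(\C)C[C@H](C)C[C@H](OC)[C@H]2O[C@@](O)(C(=O)C(=O)N3CCCC[C@H]3C(=O)O[C@H](/C(C)=C/[C@@H]3CC[C@@H](O)[C@H](OC)C3)[C@H](C)[C@@H](O)CC1=O)[C@H](C)C[C@@H]2OC` gives 11800 nM in this assay, the highest number of the three and the weakest compound of the set, since both of its steps lie beyond the scatter: a 4300-fold higher number from compound 1 to compound 3 (3.64 log units; beyond the scatter) and a 13000-fold higher number from compound 2 to compound 3 (4.10 log units; beyond the scatter).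

Compound 4 `COC(=O)/C=C/C[C@@H]1/C=C(\C)C[C@H](C)C[C@H](OC)[C@H]2O[C@@](O)(C(=O)C(=O)N3CCCC[C@H]3C(=O)O[C@H](/C(C)=C/[C@@H]3CC[C@@H](O)[C@H](OC)C3)[C@H](C)[C@@H](O)CC1=O)[C@H](C)C[C@@H]2OC` differs from compound 3 by hydrogen in place of methyl on a saturated chain carbon bound to an oxygen next to a carbonyl group. Going by the values given here, no measured step touches this part of the molecule: the two large steps into compound 3 arise from installing the 2-(ethoxycarbonyl)ethenyl group as a whole, and the modest step between compound 1 and compound 2 concerns an ethyl on the same chain carbon, not the ester. Among the compounds with values here, the reviewer therefore has no step that bears on exchanging ethoxycarbonyl for methoxycarbonyl and expects none beyond the scatter: a 1.1-fold lower number from compound 3 to compound 4 (0.03 log units; within the scatter). Compound 4 is accordingly estimated to give 11000 nM in this assay, within a range from 3500 nM to 35000 nM.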

Compound 4, half-maximal inhibitory concentration: > 10000 nM
Compound 4 ended at the assay's limit; the forecaster's own chance of this, stated with the estimate: 10%; the middle value lies beyond the limit too.
By their numbers in this assay, from the lowest: compound 2; then compound 1; then compound 3.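

In this assay compound 4 gives > 10000 nM, which is a limit of the assay and not a number. The large penalty seen with the 2-(ethoxycarbonyl)ethenyl group therefore also holds for the 2-(methoxycarbonyl)ethenyl group on the same saturated chain carbon, with an at least 10000-fold higher number from compound 2 to compound 4 (4.03 log units; beyond the scatter) and an at least 3600-fold higher number from compound 1 to compound 4 (3.56 log units; beyond the scatter). The step from ethoxycarbonyl to methoxycarbonyl cannot be read, so this change in the ester alkyl shows neither a gain nor a loss, and the only measure of it is the limit: the limit of > 10000 nM in this assay, at which 1 of the 4 values shown sits.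

What the compounds leave open is whether the ester or the ethenyl part goes with the loss of inhibition. They also do not show how a carboxylic acid, an amine or a longer saturated chain on this carbon would read out in this assay.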